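Removing one more fluoro from the sulfonamide series

The source may report more compounds than this note shows. Statements on the series, on what has been measured and on what is new or still open speak of the compounds shown alone.

Measured in a functional assay on HeLa cells (Homo sapiens) for cytotoxicity; on this read-out higher numbers stand for weaker inhibition of growth and lower numbers for stronger inhibition of growth:
compound 1 `COc1ccc(NS(=O)(=O)c2c(F)cc(F)c(F)c2F)cc1`: 5800 nM
compound 2 `COc1ccc(NS(=O)(=O)c2ccc(F)c(F)c2F)cc1`: > 50000 nM (a limit)

Within the data shown here, compound 1 at 5800 nM holds the only actual number in this assay so far. Compound 2 at > 50000 nM is a limit of the assay.

Compound 3 `COc1ccc(NS(=O)(=O)c2c(F)cc(F)cc2F)cc1` differs from compound 1 by hydrogen in place of fluoro on an aromatic carbon ortho to two fluoro groups, meta to a large group and para to a fluoro group.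

Among the measured compounds shown here, one measured step bears on this change: an at least 8.6-fold higher number from compound 1 to compound 2 (0.93 log units; beyond the scatter) is the same kind of replacement, made on a different aromatic carbon. Its size rests on the limit of > 50000 nM in this assay, at which 1 of the 2 values shown sits, and so is bounded on one side only.

With a single precedent at another carbon, a shift in the same direction is expected in this assay but with uncertain size, and a limit rather than a number remains possible. The estimated step is a 3.4-fold higher number from compound 1 to compound 3 (0.54 log units; beyond the scatter) toward weaker inhibition of growth. For compound 3 the expected value is 20000 nM with an estimated range from 7000 nM to 60000 nM in this read-out.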

Compound 3, concentration for 50% growth inhibition: > 50000 nM
Compound 3 gave a limit, no number (the forecaster's own chance of this, stated with the estimate: 35%); middle value at least 2.5-fold (0.39 log units) away from the limit.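

In this assay, the fluoro ortho to two fluoro groups and para to a fluoro group proves as necessary to growth inhibition as the fluoro removed at the other aromatic carbon, with a change to hydrogen here giving an at least 8.6-fold higher number from compound 1 to compound 3 (0.93 log units; beyond the scatter). Two separate aromatic carbons now show a shift in the same direction, since the earlier replacement gave an at least 8.6-fold higher number from compound 1 to compound 2 (0.93 log units; beyond the scatter), so the activity of compound 1 does not survive either single replacement of fluoro by hydrogen. Neither step has a measured end point, and their sizes cannot be ranked against each other: the limit of > 50000 nM in this assay, at which 2 of the 3 values shown sit.

Compound 1, at 5800 nM, remains the only compound with an actual number in this assay, so the full size of each loss stays unknown, and the compounds shown give no value on the stronger side of it. Also open, as far as these compounds go, is whether a group other than hydrogen, such as chloro, a nitrile or an amine, could stand in place of the fluoro at this carbon and keep growth inhibition in the range of compound 1.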